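Swapping one group on the shared core: an expected step

This account rests on a few compounds, and the source may have more. Where it says the series, first, only, none or still open, it means among the compounds named here.

Of the compounds shown here, three with a shared core have been measured in a physicochemical assay for solubility, measured as kinetic solubility, at pH 6.5; a higher number here means a more soluble compound, a lower number a less soluble compound. Compound 1 `C[C@@H](c1ccc2ncccc2c1)c1nnc2ccc(-c3cccc(C#N)c3)nn12` gives 32500 nM, compound 2 `COc1ccc(-c2ccc3nnc([C@@H](C)c4ccc5ncccc5c4)n3n2)cc1F` gives 10900 nM, and compound 3 `Cc1cccc(-c2ccc3nnc([C@@H](C)c4ccc5ncccc5c4)n3n2)c1` gives 19000 nM. The number for compound 3 cannot be told apart from either of the other two, as the data show a 1.7-fold lower number from compound 1 to compound 3 (0.23 log units; within the scatter) and a 1.7-fold higher number from compound 2 to compound 3 (0.24 log units; within the scatter). Only one step among these three clears the scatter, and it is modest: a 3.0-fold lower number from compound 1 to compound 2 (0.47 log units; beyond the scatter).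

The next compound is compound 4 `CNC(=O)c1ccc(-c2ccc3nnc([C@@H](C)c4ccc5ncccc5c4)n3n2)cc1`, which carries 4-(methylcarbamoyl)phenyl in place of 3-methylphenyl on an aromatic carbon of the core: 4-(methylcarbamoyl)phenyl in place of 3-methylphenyl on an aromatic carbon. Going by the values given here, none of the measured compounds carries this group, so the three steps offer only a rough guide. They do show that, across these three compounds, exchanging the group at this place has so far moved the number only modestly. From the compounds shown here alone, on that thin evidence, no large step is expected in this assay, and the direction stays open. The estimate is a 1.2-fold lower number from compound 3 to compound 4 (0.07 log units; within the scatter), an expected step that stays inside the usual scatter. For compound 4 the expected value is 16000 nM, with an estimated range from 6000 nM to 40000 nM.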

Compound 4, solubility: 11000 nM
Compound 4: the middle estimate sits 1.5-fold (0.16 log units) above what was measured; low and high end bracket the measured number.
By their numbers in this assay, from the lowest: compounds 2, 4, 3 and 1 (each within the scatter of the next, the first and the last beyond it).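

In this assay, compound 4 shows that this position tolerates a quite different group with little effect on the number: 4-(methylcarbamoyl)phenyl has 10 heavy atoms against 7 in 3-methylphenyl, and it brings a hydrogen-bond donor and acceptor that 3-methylphenyl lacks, yet the data give a 1.7-fold lower number from compound 3 to compound 4 (0.24 log units; within the scatter). Going by these compounds alone, the comparison with the 3-fluoro-4-methoxyphenyl group gives a 1.0-fold higher number from compound 2 to compound 4 (0.00 log units; within the scatter), so these two groups cannot be told apart here, while the comparison with the 3-cyanophenyl group gives a 3.0-fold lower number from compound 1 to compound 4 (0.47 log units; beyond the scatter), a modest step that matches the one seen for compound 2, although compound 3 does not share it and stays within the scatter of compound 1. No supporting measurement is available to explain these steps.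

From the compounds shown here alone, whether an amine or a carboxylic acid on this phenyl ring would give a larger step remains open. Also unknown is whether 3-(methylcarbamoyl)phenyl would give a number like that of 4-(methylcarbamoyl)phenyl, which would show whether the place of the group on the phenyl ring matters.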